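The source may report more compounds than this note shows. Statements on the series, on what has been measured and on what is new or still open speak of the compounds shown alone.

Of the compounds shown here, three sharing one core have been tested in a functional assay on PC-3 cells (Homo sapiens) for antiproliferative activity, read by MTT assay, with a stated time of 48 h; on this read-out higher numbers stand for weaker inhibition and lower numbers for stronger inhibition. Compound 1 `CN1C(=O)C(O)(Cc2nnn[nH]2)c2ccccc21` gives 44800 nM in this assay. Compound 2 `CCN1C(=O)C(O)(Cc2nnn[nH]2)c2ccccc21` carries a methyl in place of hydrogen on a saturated chain carbon bound to an amide-type nitrogen in a ring. Compound 2 is reported only at a limit of this assay, > 100000 nM. Compound 3 `CN1C(=O)C(O)(Cc2nnn[nH]2)c2cc(Cl)ccc21` instead carries a chloro in place of hydrogen on an aromatic carbon. Compound 3 is likewise reported only at a limit, > 100000 nM. The two changes gave an at least 2.2-fold higher number from compound 1 to compound 2 (0.34 log units; beyond the scatter) and an at least 2.2-fold higher number from compound 1 to compound 3 (0.34 log units; beyond the scatter). Compound 3 thus stands at the limit of > 100000 nM in this assay, at which 2 of the 3 values shown sit.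

Compound 4 `CCN1C(=O)C(O)(Cc2nnn[nH]2)c2cc(Cl)ccc21` differs from compound 3 by methyl in place of hydrogen on a saturated chain carbon bound to an amide-type nitrogen in a ring. The same change has been measured once, giving an at least 2.2-fold higher number from compound 1 to compound 2 (0.34 log units; beyond the scatter), a weakening. Compound 4 is therefore expected to remain at the limit of this assay, with a step that the limit leaves unreadable from compound 3 to compound 4 expected. Compound 4 is estimated at 200000 nM, in a range from 100000 nM to 600000 nM.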

Compound 4, half-maximal inhibitory concentration: 79300 nM
For compound 4 the middle estimate is 2.5-fold (0.40 log units) above the measured one; measured number below the stated range.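

The methyl change at this place does not act the same way on every compound: with the chloro present, it gives an at least 1.2-fold lower number from compound 3 to compound 4 (0.10 log units; that floor lies within the scatter), a floor that lies within the usual scatter, so a weakening cannot be assumed. Compared across the two cores in this assay, the gap between the methyl steps is nevertheless clear: the same change on two cores in this assay, an at least 2.2-fold higher number (0.34 log units; beyond the scatter) from compound 1 to compound 2 and an at least 1.2-fold lower number (0.10 log units; that floor lies within the scatter) from compound 3 to compound 4, at least 2.8-fold (0.44 log units) apart, beyond the scatter of two such steps. The chloro change, which here gives an at least 1.2-fold lower number from compound 2 to compound 4 (0.10 log units; that floor lies within the scatter), shows the same mismatch, so the two changes do not simply add up: the same change on two cores in this assay, an at least 2.2-fold higher number (0.34 log units; beyond the scatter) from compound 1 to compound 3 and an at least 1.2-fold lower number (0.10 log units; that floor lies within the scatter) from compound 2 to compound 4, at least 2.8-fold (0.44 log units) apart, beyond the scatter of two such steps.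

Going by these compounds, the full size of both new steps stays open, with compound 2 and compound 3 known only as limits. Also open, on these data alone, is whether a longer chain, such as propyl in place of the ethyl, or a bromo or methoxy in place of the chloro, would follow compound 4 or the limit.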